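Benzyl variation in a triazole-linked cytotoxicity series

The source may hold more compounds than are shown below. What is called first, only, known or untested is meant among the compounds shown, and "the series" means these compounds.

Compound 1 `O=c1ccoc2cc(OCc3cn(Cc4cccc(Br)c4)nn3)ccc12`: a limit of > 100000 nM
Compound 2 `O=c1ccoc2cc(OCc3cn(Cc4ccc(Br)cc4)nn3)ccc12`: a limit of > 100000 nM
Compound 3 `O=c1ccoc2cc(OCc3cn(Cc4ccccc4Cl)nn3)ccc12`: a limit of > 100000 nM

In a functional assay on SGC-7901 cells (Homo sapiens) for cytotoxicity, read by MTT assay, with a stated time of 48 h (on this read-out lower numbers stand for stronger inhibition and higher numbers for weaker inhibition), compound 1 gives only the limit > 100000 nM, not a number. In this assay compound 2 likewise gives only the limit > 100000 nM. Compound 3 also stands at the limit > 100000 nM, so its position on the scale is known only as a bound. The three single-site steps among them, a step that the two limits leave unreadable from compound 1 to compound 2, a step that the two limits leave unreadable from compound 1 to compound 3 and a step that the two limits leave unreadable from compound 2 to compound 3, therefore cannot be sized, because of the limit of > 100000 nM in this assay, at which 3 of the 3 values shown sit.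

The step now followed goes from compound 3 to compound 4 `N#Cc1cccc(Cn2cc(COc3ccc4c(=O)ccoc4c3)nn2)c1`: 3-cyanophenyl in place of 2-chlorophenyl on a saturated chain carbon bound to an aromatic nitrogen. Going by the values given here, none of the measured steps bears a readable size on this change; all three merely show that the three benzyl variants so far fail to reach a number in this assay. With that, a step from compound 3 to compound 4 of a number no higher from compound 3 to compound 4 (the limit leaves the size open) is expected, meaning no step beyond the scatter in either direction. Compound 4 is therefore estimated at 100000 nM, with a range from 40000 nM to 300000 nM, and most likely it too will be reported only as a limit.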

Compound 4, half-maximal inhibitory concentration: > 100000 nM
Compound 4: only a limit was reported (the forecaster's own chance of this, stated with the estimate: 80%); the middle value lies on the limit itself.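

In this assay compound 4 also gives only a limit (> 100000 nM). None of its steps from compound 1, compound 2 or compound 3 can be read, because all the values rest on one limit: the limit of > 100000 nM in this assay, at which 4 of the 4 values shown sit. The compounds shown leave open whether any benzyl variation on the shared core reaches a measurable value in this assay at all.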